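The compounds below may be only part of what the source reports. "The series", "measured", "known", "first", "only" and "open" are said of these compounds alone.

Working notes on the series. Three members are measured: compound 1 `COc1ccc(C(=O)NNc2nc3ccccc3nc2Cc2ccccc2)cc1`, compound 2 `O=C(Cn1c(=O)c(Cc2ccccc2)nc2ccccc21)NNC(=O)c1ccc(Cl)cc1` and compound 3 `O=C(Cn1c(=O)c(Cc2ccccc2)nc2ccccc21)N/N=C/c1ccccc1`. In an assay for inhibition of Amine oxidase [flavin-containing] B (Bos taurus), read by fluorescence, with a stated time of 60 min (a higher number here means a weaker inhibitor, a lower number a stronger inhibitor), compound 1 gives 920000 nM, compound 2 gives 880000 nM and compound 3 gives 880000 nM. For the measured compounds named here, compound 3 stands level with compound 2 at the digits reported, and its gap to compound 1 is also within the scatter, so no measured compound separates from the others in this assay. Going by the values given here, the one single-place step in the set, no change at the digits printed from compound 2 to compound 3 (within the scatter), is flat. Compound 4 `O=C(Cn1c(=O)c(Cc2ccccc2)nc2ccccc21)N/N=C/c1ccc(Br)cc1` is not yet measured; it differs from compound 3 by bromo in place of hydrogen on an aromatic carbon. Among the compounds with values here, no measured step bears directly on a bromo substituent. Within the data shown here, the only step available, no change at the digits printed from compound 2 to compound 3 (within the scatter), exchanged the entire aryl-bearing group without moving the number, which gives no sign that a change on that ring is felt in this assay. For compound 4 the step of no change at the digits printed from compound 3 to compound 4 (within the scatter) is therefore expected to stay within the scatter, in no set direction. Compound 4 is estimated at 880000 nM in this assay, with a range from 400000 nM to 1800000 nM.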

Compound 4, half-maximal inhibitory concentration: 26000 nM
Compound 4: the middle estimate sits 34-fold (1.53 log units) above what was measured; the whole stated range lies above it.
By their numbers in this assay, from the lowest: compound 4; then compounds 2, 3 and 1 (each within the scatter of the next).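

In this assay, bromo in place of hydrogen on the six-membered aromatic ring, para to a large group, gives a 34-fold lower number from compound 3 to compound 4 (1.53 log units; beyond the scatter). This place on the ring is therefore felt in this assay, which the flat step no change at the digits printed from compound 2 to compound 3 (within the scatter) did not reveal. The exchange of the whole group on the amide-type nitrogen gives a 34-fold lower number from compound 2 to compound 4 (1.53 log units; beyond the scatter), so that group can move the number even though compound 2, which carries a chlorine in its group, stands level with compound 3. Nothing on hand accounts for the effect of the bromo group.

As far as these compounds go, whether the drop is specific to bromo remains open, as a chloro, methyl or methoxy group at the same place could be compared with it. Also open, from the compounds shown here alone, is whether bromo at other places on that ring, or on the phenyl of compound 1, has any such effect.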